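A few compounds are considered here, and "the series" means these few. Any claim that something is new, unique, unknown or untested is made for them only; others in the source may bear on it.

Measured so far: compound 1 `Cc1ccc(S(=O)(=O)NCc2ccc(CNC(=O)c3ccc(F)cc3)cc2)cc1`, 1 nM; compound 2 `O=C(NCc1ccc(CNS(=O)(=O)c2ccccc2)cc1)c1cccnc1`, 10 nM.

In an assay on MDA-MB-231 cells for binding affinity to C-X-C chemokine receptor type 4 (Homo sapiens), read by immunofluorescence and microscopy, with stated times of 10 min and 30 min (a higher number here means that more compound is needed for the effect, a lower number that less compound is needed), compound 1 gives 1 nM, the lowest of the two numbers. Compound 2 gives 10 nM, a higher number, beyond the scatter. Compound 3 `Cc1ccc(S(=O)(=O)NCc2ccc(CNC(=O)c3cccc(C)c3)cc2)cc1` has not yet been measured. It differs from compound 1 in one place: 3-methylphenyl in place of 4-fluorophenyl on a carbonyl carbon. Within the data shown here, no measured pair shows this change, so nothing is known of its size. The step from compound 1 to compound 3 is expected to be small, a 2.0-fold higher number from compound 1 to compound 3 (0.30 log units; within the scatter), staying within the scatter. Compound 3 is therefore estimated at 2 nM, in the range 0.5 nM to 8 nM.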

Compound 3, effective concentration (reported as EC, without a stated level of effect): 1000 nM
Compound 3: middle estimate off by 500-fold (2.70 log units), on the low side, and the stated range ends below it.
By their numbers in this assay, from the lowest: compound 1; then compound 2; then compound 3.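

In this assay, among these compounds, 3-methylphenyl in place of 4-fluorophenyl on a carbonyl carbon gives a 1000-fold higher number from compound 1 to compound 3 (3.00 log units; beyond the scatter) and so shows that this position, which no earlier pair had tested, is highly sensitive to the group it carries. The two groups have the same heavy-atom count and the same counts of hydrogen-bond donors and acceptors, so these counts do not track the step. Nothing available accounts for the size of this step.

The change alters both the substituent and its place on the ring, and the compounds shown do not separate the two. Going by these compounds, whether 4-methylphenyl or 3-fluorophenyl at this carbonyl carbon would give a number nearer that of compound 1 or that of compound 3 remains open.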